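This account rests on a few compounds, and the source may have more. Where it says the series, first, only, none or still open, it means among the compounds named here.

Compound 1 `CC(C)C(C(N)=O)c1ccc(Cl)cc1` heads the series. In a functional assay on CHO cells for agonist activity at Free fatty acid receptor 2 (Homo sapiens), read by cAMP accumulation (on this read-out higher numbers stand for weaker inhibition and lower numbers for stronger inhibition), compound 1 gives only a limit, > 100000 nM, not a number. Compound 2 `CC(C)[C@H](C(=O)Nc1nnc(C(F)(F)F)s1)c1ccc(Cl)cc1`, which bears a substituent on the amide nitrogen, gives 1900 nM in this assay. Compound 3 `CC(C)C(C(=O)Nc1nnn[nH]1)c1ccc(Cl)cc1` differs from compound 1 by 1H-tetrazol-5-yl in place of hydrogen on an amide-type nitrogen. Within the data shown here, no step between measured compounds is available to calibrate this change; the expected step is an at least 20-fold lower number from compound 1 to compound 3 (1.30 log units; beyond the scatter), toward stronger inhibition, since compound 2 with its substituted amide nitrogen shows 1900 nM. Compound 3 is expected to reach 5000 nM, with a range of 800 nM to 40000 nM.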

Compound 3, half-maximal inhibitory concentration: 100000 nM
Beside the measured number, compound 3's estimate is 20-fold (1.30 log units) below it; measured number outside the range, above it.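

Substitution on the amide-type nitrogen does not by itself give a low number: with 1H-tetrazol-5-yl in place of hydrogen, compound 3 gives 100000 nM in this assay. The data show a number no higher from compound 1 to compound 3 (the limit leaves the size open) for this change. The size of the step from the unsubstituted amide cannot be read because compound 1 is held only by a limit: the limit of > 100000 nM in this assay, at which 1 of the 3 values shown sits.

Open, from the compounds shown here alone, is how a simple chain such as methyl or a phenyl group on the same nitrogen would read. Also open, going by these compounds, is whether a carboxylic acid in place of the whole amide would give a measurable number.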